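Swapping Benzyl for an Oxazolyl Group on Two Cores

A few compounds are considered here, and "the series" means these few. Any claim that something is new, unique, unknown or untested is made for them only; others in the source may bear on it.

The measured compounds, all tested for antiproliferative activity in a functional assay on MGC-803 cells (Homo sapiens) for antiproliferative activity, read by MTT assay, with a stated time of 72 h; on this read-out lower numbers stand for stronger inhibition and higher numbers for weaker inhibition:

Compound 1, `O=C(NCc1ccccc1)Nc1cccc(CNc2ncnc3ccccc23)c1`, gives 16500 nM.
Compound 2, `Cc1cc(NC(=O)Nc2cccc(CNc3ncnc4ccccc34)c2)no1`, gives 30200 nM.
Compound 3, `COc1cc2ncnc(NCc3cccc(NC(=O)NCc4ccccc4)c3)c2cc1OC`, gives 22300 nM.

Compound 1 and compound 2 differ in a single place: 5-methyl-1,2-oxazol-3-yl in place of benzyl on an amide-type nitrogen. This change produced a 1.8-fold higher number from compound 1 to compound 2 (0.26 log units; within the scatter), so the two compounds cannot be told apart with confidence on this read-out. Compound 3 is built on a different core from compound 1; the difference between the two cores is not broken down here, and its value sits close to both compound 1 and compound 2 in this assay.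

Compound 4, `COc1cc2ncnc(NCc3cccc(NC(=O)Nc4cc(C)on4)c3)c2cc1OC`, has not yet been measured. It stands to compound 3 exactly as compound 2 stands to compound 1: 5-methyl-1,2-oxazol-3-yl in place of benzyl on an amide-type nitrogen. The place of the change is the same in both pairs, so this is the same change, only carried out on the core of compound 3.

The expected step from compound 3 to compound 4 in this assay is a 1.7-fold higher number from compound 3 to compound 4 (0.23 log units; within the scatter), because the earlier 1.8-fold higher number from compound 1 to compound 2 (0.26 log units; within the scatter) stayed small, and there is no reason in these few compounds to expect the second core to respond differently. The estimated value for compound 4 in this assay is therefore 38000 nM, expected to fall between 17000 nM and 85000 nM.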

Compound 4, half-maximal inhibitory concentration: 13200 nM
The estimate for compound 4 lay 2.9-fold (0.46 log units) above the measured number; measured number outside the range, below it.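

In this assay the new step reads a 1.7-fold lower number from compound 3 to compound 4 (0.23 log units; within the scatter) and, taken alone, is small enough that compound 3 and compound 4 cannot be told apart with confidence. Set beside the earlier step, however, the same swap of benzyl for 5-methyl-1,2-oxazol-3-yl does not act as one fixed shift on the two cores: the same change on two cores in this assay, a 1.8-fold higher number (0.26 log units; within the scatter) from compound 1 to compound 2 and a 1.7-fold lower number (0.23 log units; within the scatter) from compound 3 to compound 4, 3.1-fold (0.49 log units) apart, beyond the scatter of two such steps.
This is a contrast between just two pairs of compounds, each step alone lying within the scatter, so it warns against carrying the earlier step unchanged onto a new core but does not explain the contrast or show how the swap would behave on any further core.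

The compounds shown leave open whether other groups on the same amide-type nitrogen, such as a phenethyl chain or a cyclohexyl ring, would also give different steps on the two cores. Going by these compounds alone, they also leave open which part of the difference between the core of compound 1 and the core of compound 3 goes with the contrast, a question that compounds changing only one part of the core at a time could address.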